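The source may report more compounds than this note shows. Statements on the series, on what has been measured and on what is new or still open speak of the compounds shown alone.

Working notes on the series. Compound 1 `Nc1nc(O)c2c(n1)n(C1OC(CO)[C@@H](O)[C@H]1O)c(=O)n2Cc1ccc(Cl)c(Cl)c1` is the point of departure; in a functional assay on the whole organism with Mus musculus as the target (a lower number here means a smaller maximal response, a higher number a larger maximal response), compound 1 gives 0%. Compound 2 `COc1ccc(Cn2c(=O)n(C3OC(CO)[C@@H](O)[C@H]3O)c3nc(N)nc(O)c32)cc1` in this assay gives 14%, and compound 3 `CCCCCCCCCCn1c(=O)n(C2OC(CO)[C@@H](O)[C@H]2O)c2nc(N)nc(O)c21` gives 0%. Among the measured compounds compound 3 stands level with compound 1, the two together at the lowest of the three numbers: no change at the digits printed from compound 1 to compound 3 (within the scatter). Among the measured compounds shown here, the only step that rises is a number 14 percentage points higher from compound 1 to compound 2 (beyond the scatter), and the reverse side of that is a number 14 percentage points lower from compound 2 to compound 3 (beyond the scatter).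

Compound 4 `CCCCCCn1c(=O)n(C2OC(CO)[C@@H](O)[C@H]2O)c2nc(N)nc(O)c21` is not yet measured; it differs from compound 3 by hydrogen in place of butyl on a saturated chain carbon, six bonds along the chain from an aromatic nitrogen. For the measured compounds named here, no measured step changes the chain alone: every step so far swaps the whole group on the saturated chain carbon bound to an aromatic nitrogen, and the one that puts a chain there, no change at the digits printed from compound 1 to compound 3 (within the scatter), is within the scatter. Shortening the chain in compound 4 is therefore expected to leave this assay unchanged, a step of a number 2 percentage points higher from compound 3 to compound 4 (within the scatter) at most. The estimate for compound 4 is 2%, with a range from 0% to 12%.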

Compound 4, largest response reached (reported as maximal response), in percent of the reference or control that the assay uses: 11%
Estimate against measurement, compound 4: 9 percentage points below; the measured number falls inside the stated range.
By their numbers in this assay, from the lowest: compounds 1 and 3 (each within the scatter of the next); then compounds 4 and 2 (each within the scatter of the next).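

In this assay, among the compounds shown here, this is the first step that changes the chain alone: hydrogen in place of butyl on a saturated chain carbon, six bonds along the chain from an aromatic nitrogen, gives a number 11 percentage points higher from compound 3 to compound 4 (beyond the scatter), so the position responds to chain length and not only to swapping the whole group. A chain at this place therefore does not by itself hold the number at the bottom of the series: pentyl in place of 3,4-dichlorophenyl gives a number 11 percentage points higher from compound 1 to compound 4 (beyond the scatter), while pentyl in place of 4-methoxyphenyl gives a number 3 percentage points lower from compound 2 to compound 4 (within the scatter). Nothing available explains this difference.

Going by these compounds, with only two chains in hand, the shape of the dependence on chain length remains open. A propyl chain, or a hexyl chain ending in an amine or a carboxylic acid, would test how far this trend extends.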